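The source may report more compounds than this note shows. Statements on the series, on what has been measured and on what is new or still open speak of the compounds shown alone.

Compound 1 `Cc1cccc(CN2CCC=C(CCC(=O)NO)C2=O)c1` — this assay: > 10000 nM
Compound 2 `COc1ccc(CN2CCC=C(CCC(=O)NO)C2=O)cc1` — this assay: 6890 nM
Compound 3 `O=C(CCC1=CCCN(CCCc2ccc(-c3ccccc3)cc2)C1=O)NO` — this assay: 3190 nM

Three hydroxamic acids built on a shared core were tested in a functional assay on HCT-15 cells (Homo sapiens) for inhibition, read by sulforhodamine B assay; a lower number here means a stronger inhibitor of growth, a higher number a weaker inhibitor of growth. Compound 2 stands at the top of the two numbers reported, with 6890 nM. Compound 3 gives 3190 nM, a lower number, and the gap between compound 3 and compound 2 lies beyond the usual scatter. Compound 1 returns only a limit of the assay, (the limit of > 10000 nM in this assay, at which 1 of the 3 values shown sits), so it is not a number and cannot be ranked.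

Compound 4 `O=C(CCC1=CCCN(Cc2ccc(NC(=O)c3ccccc3)cc2)C1=O)NO` has not yet been measured. It differs from compound 2 in one place: benzamido in place of methoxy on an aromatic carbon. For the measured compounds named here, no step between measured compounds maps onto this exact change. What the measured compounds do show is that compound 3, which carries the largest aryl substituent of the three, also shows the lowest number in this assay, while compound 2 with its methoxy sits higher. On that basis the step from compound 2 to compound 4 is expected to be a modest drop, a 2.3-fold lower number from compound 2 to compound 4 (0.36 log units; beyond the scatter), beyond the scatter but not large. Compound 4 is therefore estimated at 3000 nM, with a range from 1000 nM to 10000 nM.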

Compound 4, concentration for 50% growth inhibition: > 10000 nM
Compound 4: only a limit was reported; the forecaster's own chance of this, stated with the estimate: 15%; middle value at least 3.3-fold (0.52 log units) away from the limit.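

In this assay compound 4 gives > 10000 nM, which is a limit of the assay and not a number. Exchanging methoxy for benzamido, on an aromatic carbon para to a large group, adds a six-membered aromatic ring and a hydrogen-bond donor, yet the number does not fall: the change reads as an at least 1.4-fold higher number from compound 2 to compound 4 (0.16 log units; that floor lies within the scatter), so this position gains nothing measurable in growth inhibition from the larger group, though a rise beyond the scatter cannot be established from a floor of this size. The limit is also no longer confined to a single compound in the set: the limit of > 10000 nM in this assay, at which 2 of the 4 values shown sit.

The compounds shown leave open how far compound 4 actually lies beyond the limit, and therefore how large the step truly is. They also leave open whether the outcome belongs to benzamido alone or extends to other groups on this aromatic carbon, such as an amine, a carboxylic acid or an acetamido group, any of which could show whether this position tolerates a replacement for methoxy at all.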